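Nitrile-bearing pyrazole series: acetyl to dimethylamino exchange

The source may report more compounds than this note shows. Statements on the series, on what has been measured and on what is new or still open speak of the compounds shown alone.

Compound 1 `COc1cc(C)cc(-c2c(-c3ccnc(-c4ccc(C(C)=O)cc4)c3)cnn2CC#N)c1` carries an acetyl group on the outer phenyl ring of the shared core. In a functional assay on SNB-19 cells (Homo sapiens) for inhibition, read by sulforhodamine B assay, with a stated time of 48 h (a lower number here means that less compound is tolerated, a higher number that more compound is tolerated), compound 1 gives > 100000 nM, which is a limit of the assay rather than a number. Compound 2 `COc1cc(C)cc(-c2nn(CC#N)cc2-c2ccnc(-c3ccc(N(C)C)cc3)c2)c1` carries a dimethylamino group on its outer phenyl ring but differs from compound 3 elsewhere in the core. In this assay compound 2 gives > 100000 nM, again only a limit. Taken together, the limit of > 100000 nM in this assay, at which 2 of the 2 values shown sit, describes everything measured so far in this series: no numerical value has yet emerged. Compound 3 `COc1cc(C)cc(-c2c(-c3ccnc(-c4ccc(N(C)C)cc4)c3)cnn2CC#N)c1` remains to be tested; it differs from compound 1 by dimethylamino in place of acetyl on an aromatic carbon. Among the compounds with values here, no step between measured compounds covers this exchange. The expected step is a number no higher from compound 1 to compound 3 (the limit leaves the size open), which amounts to none beyond the scatter, since the dimethylamino-bearing compound 2 also only reached a limit. Compound 3 is accordingly estimated at 100000 nM, with a range from 30000 nM to 300000 nM, and most probably reported once more as a limit rather than a number.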

Compound 3, concentration lethal to 50% of the cells: > 100000 nM
Compound 3 ended at the assay's limit; the forecaster's own chance of this, stated with the estimate: 80%; the middle value sits exactly at the limit.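

No step can be read from compound 1 to compound 3, since both results are limits of the assay rather than numbers: the limit of > 100000 nM in this assay, at which 3 of the 3 values shown sit. The compounds shown leave open how large the effect of exchanging acetyl for dimethylamino is in this assay, and whether any compound of this series gives a numerical value there.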